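The compounds below may be only part of what the source reports. "The series", "measured", "known", "first", "only" and "open" are said of these compounds alone.

Compound 2 `CCOC(=O)c1c(Nc2ccc(I)cc2F)sc2c1CC(C)(C)CNC2=O` carries an ethoxycarbonyl on the shared core, and in a functional assay on HT-29 cells (Homo sapiens) for antiproliferative activity (a higher number here means a weaker inhibitor, a lower number a stronger inhibitor), compound 2 gives "not determined" (no result reported), so it stands nowhere on the numbers shown. Its close relatives are compound 1 `CC1(C)CNC(=O)c2sc(Nc3ccc(I)cc3Cl)c(C(=O)NCC[C@@H](O)CO)c2C1` and compound 3 `CC1(C)CNC(=O)c2sc(Nc3ccc(I)cc3Cl)c(C(=O)NC[C@@H](O)CO)c2C1`, which carry the same core with a chloro instead of a fluoro substituent and a carboxamide in place of the ester. In this assay compound 1 gives 12100 nM, while compound 3 gives 710 nM, the step being a 17-fold lower number from compound 1 to compound 3 (1.23 log units; beyond the scatter).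

Compound 4 `CC(C)(N)CNC(=O)c1c(Nc2ccc(I)cc2F)sc2c1CC(C)(C)CNC2=O` arises from compound 2 through ((2-amino-2-methylpropyl)amino in place of ethoxy on a carbonyl carbon). For the measured compounds named here, no measured pair describes this ester-to-amide exchange, and the only recorded step concerns the length of a dihydroxyalkyl chain on an amide nitrogen, so it bears on the change only indirectly by showing that the amide substituent can shift this assay by a large amount. Compound 4 is therefore expected, with wide uncertainty, to land around 700 nM in this assay, somewhere between 100 nM and 6000 nM.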

Compound 4, half-maximal inhibitory concentration: 79 nM
Estimate against measurement, compound 4: 8.9-fold (0.95 log units) above; measured number outside the range, below it.
By their numbers in this assay, from the lowest: compound 4; then compound 3; then compound 1.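

For the compounds shown here, with no single number for compound 2 in this assay, no step from compound 2 to compound 4 can be read. The compounds shown leave open what (2-amino-2-methylpropyl)amino in place of ethoxy does on its own in this assay. Nothing shown offers an explanation for the result of compound 4.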